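Phenyl to hydroxy on the bridged core of compound 1

The source may report more compounds than this note shows. Statements on the series, on what has been measured and on what is new or still open speak of the compounds shown alone.

Measured so far:
compound 1, `c1ccc(-c2cccc3c2C2CNCC3C2)cc1`, 1600 nM
compound 2, `CCCn1c(C)nc2cc3c(cc21)C1CNCC3C1`, 0.19 nM
compound 3, `Cn1cnc2cc3c(cc21)C1CNCC3C1`, 0.75 nM

The three numbers come from an assay on HEK293 cells for binding affinity to Neuronal acetylcholine receptor; alpha4/beta2 (Homo sapiens); a higher number here means a weaker inhibitor, a lower number a stronger inhibitor. Compound 1 stands highest of the three: compound 3 lies a good deal lower, and compound 2 lower still, both differences well beyond the scatter. Among the measured compounds shown here, compound 2 and compound 3 share a different core from compound 1, so no single step connects them to it; their values show only that the bridged amine can reach very low numbers when the aromatic part is built differently.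

Compound 4, `Oc1cccc2c1C1CNCC2C1`, differs from compound 1 in one place: hydroxy in place of phenyl on an aromatic carbon. For the measured compounds named here, no measured pair shows this change, so the size of the step can only be guessed. Given the high number of compound 1 at 1600 nM, the expectation for compound 4 is a somewhat lower number, a step of moderate size and probably beyond the scatter, though a result within the scatter cannot be excluded. The estimate for compound 4 is 300 nM, with a range of 30 nM to 3000 nM, which means an expected step of a 5.3-fold lower number from compound 1 to compound 4 (0.73 log units; beyond the scatter).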

Compound 4, inhibition constant: 1700 nM
Compound 4: middle estimate off by 5.7-fold (0.75 log units), on the low side; low and high end bracket the measured number.
By their numbers in this assay, from the lowest: compound 2; then compound 3; then compounds 1 and 4 (each within the scatter of the next).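

In this assay the exchange of phenyl for hydroxy on this aromatic carbon, ortho to a fused ring and meta to a fused ring, gives a 1.1-fold higher number from compound 1 to compound 4 (0.03 log units; within the scatter) and so leaves the number unmoved on the core of compound 1. At this position, phenyl with 6 heavy atoms and one six-membered aromatic ring reads the same as hydroxy with 1 heavy atom, 1 hydrogen-bond donor and 1 hydrogen-bond acceptor, so neither the removal of that ring nor the arrival of the donor and acceptor shows up in this read-out. Nothing at hand offers a reason for this flat result.

From the compounds shown here alone, whether the same flat reading holds for other groups on this aromatic carbon, such as an amine, a methoxy group, a carboxylic acid or a longer chain, remains open, as does the case of this carbon carrying only hydrogen. Also open, going by these compounds, is whether phenyl and hydroxy would still read alike on another aromatic carbon of the core of compound 1.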